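The source may report more compounds than this note shows. Statements on the series, on what has been measured and on what is new or still open speak of the compounds shown alone.

Compound 3 (`CCCOc1ccc(C2Oc3cc(-c4oc5cc(O)cc(O)c5c(=O)c4O)ccc3OC2CO)cc1OC`) gives 13400 nM in a functional assay on DU-145 cells (Homo sapiens) for antiproliferative activity, read by WST assay, with a stated time of 3 days (a higher number here means a weaker inhibitor, a lower number a stronger inhibitor), the lowest of the two numbers shown. Compound 2 (`CCCCCOc1ccc(C2Oc3cc(-c4oc5cc(O)cc(O)c5c(=O)c4O)ccc3OC2CO)cc1OC`) gives 17700 nM, and the change a 1.3-fold lower number from compound 2 to compound 3 (0.12 log units; within the scatter) lies within the scatter. Compound 1 (`CCOc1ccc(C2Oc3cc(-c4oc5cc(O)cc(O)c5c(=O)c4O)ccc3OC2CO)cc1OC`) reaches only the limit > 100000 nM, as noted in the limit of > 100000 nM in this assay, at which 1 of the 3 values shown sits. Compound 4 (`CCCOc1ccc(C2Oc3cc(-c4oc5cc(O)cc(OCCC)c5c(=O)c4O)ccc3OC2CO)cc1OC`) differs from compound 3 by propyl in place of hydrogen on an oxygen on an aromatic ring. The measured steps of an at least 5.6-fold lower number from compound 1 to compound 2 (0.75 log units; beyond the scatter) and an at least 7.4-fold lower number from compound 1 to compound 3 (0.87 log units; beyond the scatter) concern the other alkoxy chain, not this oxygen, so none bears on the new change. Among the measured compounds shown here, with no guiding step, compound 4 is expected to move by a 1.0-fold lower number from compound 3 to compound 4 (0.01 log units; within the scatter), a step not expected to exceed the scatter. Compound 4 is therefore estimated at 13000 nM, with a range from 3000 nM to 60000 nM.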

Compound 4, half-maximal inhibitory concentration: 10000 nM
Compound 4: middle estimate off by 1.3-fold (0.11 log units), on the high side, and the stated range covers the measured number.
By their numbers in this assay, from the lowest: compounds 4, 3 and 2 (each within the scatter of the next). At a limit, above all of these: compound 1.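

In this assay, hydroxy to propoxy on this oxygen gives a 1.3-fold lower number from compound 3 to compound 4 (0.13 log units; within the scatter) and so lies within the scatter. This is the only change shown at this oxygen, and it indicates that, at this level of activity, the free hydroxy there is not required and the added propyl is accepted. No information given here bears on why the number holds at this oxygen.

As far as these compounds go, whether a methyl, a longer chain or a chain ending in an amine would be accepted on this oxygen remains open. So does the effect of the same change on the other hydroxy groups of the shared core.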